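Dimethoxy for Dichloro on the Side Chain of Compound 3

The source may hold more compounds than are shown below. What is called first, only, known or untested is meant among the compounds shown, and "the series" means these compounds.

Compound 1 `Nc1cc(N)c2nc(-c3ccccc3)c(Oc3ccc(Cl)c(Cl)c3)nc2c1` gives 6030 nM in a functional assay on RXF 393 cells (Homo sapiens) for inhibition, read by sulforhodamine B assay, with a stated time of 48 h; on this read-out lower numbers stand for stronger inhibition of growth and higher numbers for weaker inhibition of growth.
Compound 2 `CCOC(=O)[C@H](CCC(=O)O)NC(=O)c1ccc(CNc2nc3cc(N)cc(N)c3nc2-c2ccccc2)cc1` gives only a limit of the assay, < 100000 nM.
Compound 3 `Nc1cc(N)c2nc(-c3ccccc3)c(NCc3ccc(Cl)c(Cl)c3)nc2c1` gives 3090 nM.

Two of the three compounds share the same core and differ only in the group attached to it; the third, compound 2, carries a longer side chain and reports (the limit of < 100000 nM in this assay, at which 1 of the 3 values shown sits). Among the two real numbers, compound 3 shows the lowest value, but its nearest neighbour, compound 1, sits within the usual scatter of repeated measurements, so the two cannot be told apart in strength.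

The next compound, compound 4 `COc1ccc(CNc2nc3cc(N)cc(N)c3nc2-c2ccccc2)cc1OC`, is not yet measured. It differs from compound 3 in one place: 3,4-dimethoxyphenyl in place of 3,4-dichlorophenyl on a saturated chain carbon bound to a nitrogen on an aromatic ring. Going by the values given here, no measured pair shows this exchange, so there is no direct guide to its size. For compound 4 a somewhat weaker inhibition is expected, as a step of a 2.3-fold higher number from compound 3 to compound 4 (0.36 log units; beyond the scatter) that may sit just beyond the scatter. The estimate for compound 4 is 7000 nM, with a range from 2000 nM to 25000 nM.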

Compound 4, concentration for 50% growth inhibition: 19100 nM
Compound 4: middle estimate off by 2.7-fold (0.44 log units), on the low side, and the stated range covers the measured number.
By their numbers in this assay, from the lowest: compounds 3 and 1 (each within the scatter of the next); then compound 4.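

The earlier compounds shown here offered no step, so the group at the end of the chain could not be judged on its own. Now, with the shared core and the saturated chain carbon unchanged, in this assay putting 3,4-dimethoxyphenyl in place of 3,4-dichlorophenyl gives a 6.2-fold higher number from compound 3 to compound 4 (0.79 log units; beyond the scatter) and so weakens growth inhibition. This position is therefore not indifferent to what the ring carries: the six-membered aromatic ring of carbon stays, and changing only the two chlorine atoms to two methoxy groups is enough for a step beyond the usual scatter. No measurement shown explains why the step has this size.

One exchange cannot tell whether the loss comes from both methoxy groups together or from just one of them, or whether it comes from losing the chlorine atoms or from adding the methoxy groups. On these data alone, it also remains open how this series would respond to a plain phenyl ring, to a ring with a single chlorine, or to a ring carrying a trifluoromethyl group or an amine.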